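Fluorines on the aryl ketone in a pyrazolyl chalcone series

The source may report more compounds than this note shows. Statements on the series, on what has been measured and on what is new or still open speak of the compounds shown alone.

Going by the values given here, the two compounds measured so far share one core. Compound 1 `COc1ccc(C(=O)/C=C/c2cc(-c3cc(OC)c(OC)c(OC)c3)n[nH]2)cc1OC` carries two methoxy groups on the aryl ring attached to the carbonyl, and compound 2 `COc1ccc(C(=O)/C=C/c2cc(-c3cc(OC)c(OC)c(OC)c3)n[nH]2)cc1` carries one. In a functional assay on 786-0 cells (Homo sapiens) for cytotoxicity, read by sulforhodamine B assay, with a stated time of 48 h, tested at 0.1 uM (on this read-out lower numbers stand for a stronger effect and higher numbers for a weaker effect at the one concentration tested), compound 1 gives 94%, and compound 2 gives 96%. Among the compounds with values here, the single step between them, a number 2 percentage points higher from compound 1 to compound 2 (within the scatter), is a change of hydrogen in place of methoxy on an aromatic carbon of that ring; it lies within the scatter, so compound 2 stands together with compound 1, and the two cannot be told apart on these numbers.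

Compound 3 `COc1cc(-c2cc(/C=C/C(=O)c3ccc(F)c(F)c3)[nH]n2)cc(OC)c1OC` is not yet measured. It differs from compound 2 at the same ring: 3,4-difluorophenyl in place of 4-methoxyphenyl on a carbonyl carbon. Within the data shown here, the only measured step that bears on this place is the one from compound 1 to compound 2, and it was within the scatter. Nothing measured covers a fluorine substituent, so the expectation rests on that step alone. Compound 3 is therefore expected to give a number in this assay close to that of compound 2, with a step of a number 2 percentage points lower from compound 2 to compound 3 (within the scatter) that is estimated to stay within the scatter. The estimate for compound 3 is 94%, expected within the range 80% to 104%.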

Compound 3, a percentage reported as activity, at one concentration (the size of the read-out at that concentration, not a potency): 95%
The estimate for compound 3 lay 1 percentage points below the measured number, within the range that was stated.
By their numbers in this assay, from the lowest: compounds 1, 3 and 2 (each within the scatter of the next).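

In this assay, the change to 3,4-difluorophenyl on a carbonyl carbon gives a number 1 percentage points lower from compound 2 to compound 3 (within the scatter) when it replaces 4-methoxyphenyl, and a number 1 percentage points higher from compound 1 to compound 3 (within the scatter) when it replaces 3,4-dimethoxyphenyl. The earlier step only removed one methoxy and left the other in place, whereas here no methoxy remains on the ring attached to the carbonyl and fluorine stands on it instead, yet all three compounds still cannot be told apart on these numbers. Nothing available here speaks to the reason for this.

The compounds shown leave open whether any substituent at this position moves the number beyond the scatter, for instance an amine or a carboxylic acid on the same aryl ring, since methoxy, hydrogen and fluorine are the only variations seen so far. They also leave open what happens when the methoxy groups on the other aryl ring, identical in all three compounds, are exchanged, and whether the three would still stand together at a different concentration.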